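Adding a Sulfamoyl Group to Compound 2

The compounds below may be only part of what the source reports. "The series", "measured", "known", "first", "only" and "open" are said of these compounds alone.

Compound 1 `COc1ccc(OC)c(-c2cc(-c3ccccc3)nn2-c2ccc(S(N)(=O)=O)cc2)c1`: 32900 nM
Compound 2 `Oc1ccc(O)c(-c2cc(-c3ccccc3)nn2-c2ccccc2)c1`: 75700 nM
Compound 3 `Oc1ccc(O)c(-c2cc(-c3ccc(Cl)cc3)nn2-c2ccccc2)c1`: 41100 nM

Of the compounds shown here, three sharing a common core have been tested in a functional assay on cells (Cancer cell lines, Homo sapiens) for cytotoxicity, read by sulforhodamine B assay, with a stated time of 48 h; on this read-out higher numbers stand for weaker inhibition of growth and lower numbers for stronger inhibition of growth. Compound 2 `Oc1ccc(O)c(-c2cc(-c3ccccc3)nn2-c2ccccc2)c1` gives 75700 nM, the highest number of the three. Its nearest neighbour is compound 3 `Oc1ccc(O)c(-c2cc(-c3ccc(Cl)cc3)nn2-c2ccccc2)c1`, where the change is a 1.8-fold lower number from compound 2 to compound 3 (0.27 log units; within the scatter). Among the measured compounds shown here, the furthest is compound 1 `COc1ccc(OC)c(-c2cc(-c3ccccc3)nn2-c2ccc(S(N)(=O)=O)cc2)c1`, which in this assay gives 32900 nM, a gap from compound 2 that lies beyond the scatter; compound 1, however, differs from compound 2 in more than one place, so no single step connects them.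

Compound 4 `NS(=O)(=O)c1ccc(-n2nc(-c3ccccc3)cc2-c2cc(O)ccc2O)cc1` is not yet measured. Relative to compound 2 the change is sulfamoyl in place of hydrogen on an aromatic carbon. For the measured compounds named here, no measured step covers this change: the only step between neighbours is a 1.8-fold lower number from compound 2 to compound 3 (0.27 log units; within the scatter), which concerns a different position and lies within the scatter. The pair compound 1 and compound 2 merely shows that the compound carrying a sulfamoyl group gives the lower number, while also carrying other changes.

On this basis compound 4 is expected to give a somewhat lower number than compound 2, estimated as a 1.7-fold lower number from compound 2 to compound 4 (0.23 log units; within the scatter). The estimate for compound 4 in this assay is 45000 nM, with a range from 15000 nM to 130000 nM.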

Compound 4, concentration for total growth inhibition: 96000 nM
The estimate for compound 4 lay 2.1-fold (0.33 log units) below the measured number; low and high end bracket the measured number.
By their numbers in this assay, from the lowest: compounds 1, 3, 2 and 4 (each within the scatter of the next, the first and the last beyond it).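

In this assay, sulfamoyl in place of hydrogen, on an aromatic carbon para to a large group, gives a 1.3-fold higher number from compound 2 to compound 4 (0.10 log units; within the scatter), so this single change does not separate the two compounds on this read-out. With sulfamoyl held in place, 2,5-dihydroxyphenyl in place of 2,5-dimethoxyphenyl gives a 2.9-fold higher number from compound 1 to compound 4 (0.47 log units; beyond the scatter), a modest step; the lower number of compound 1 therefore goes with its 2,5-dimethoxyphenyl group and not with sulfamoyl, which the earlier comparison of compound 1 and compound 2 could not show. Nothing available explains the size of either step.

The compounds shown leave open whether a carboxylic acid or an amine on the same aromatic carbon would shift the number beyond the scatter, and whether sulfamoyl would behave in the same way alongside the chloro group of compound 3. They also do not tell whether a single methoxy group on that phenyl ring would be enough to give a number like that of compound 1, or whether both methoxy groups are required.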